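This account rests on a few compounds, and the source may have more. Where it says the series, first, only, none or still open, it means among the compounds named here.

Compound 1 `COc1ccc(-c2nc3c(NC4CCCC4)ncnc3n2C)cc1` was tested in an assay on CHO cells for displacement of a labelled ligand from adenosine receptor A3 (Homo sapiens), read by scintillation counting, with a stated time of 3 h (a higher number here means a weaker inhibitor, a lower number a stronger inhibitor), where compound 1 gives 1850 nM. Two close relatives share its core and differ only in the aryl group attached to it. Compound 2 `Cc1ccccc1-c1nc2c(NC3CCCC3)ncnc2n1C` gives 3000 nM in this assay, and compound 3 `Cn1c(-c2ccc(Cl)cc2)nc2c(NC3CCCC3)ncnc21` gives 1210 nM. Among these three numbers compound 1 holds the second highest: the step of a 1.5-fold lower number from compound 1 to compound 3 (0.18 log units; within the scatter) is within the scatter, as is the step of a 1.6-fold higher number from compound 1 to compound 2 (0.21 log units; within the scatter), so none of the three can be separated with confidence, although the step of a 2.5-fold lower number from compound 2 to compound 3 (0.39 log units; beyond the scatter) is a modest one beyond it.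

Compound 4 `Cn1c(-c2ccccc2)nc2c(NC3CCCC3)ncnc21` is the next case. Relative to compound 1 the change is hydrogen in place of methoxy on an aromatic carbon. For the measured compounds named here, the step that bears most directly on this is the one from compound 1 to compound 3, where another group replaced the methoxy at the same position and the number barely moved; the step from compound 1 to compound 2 also stayed within the scatter. With such small movements on record, no step beyond the scatter is expected here, in either direction. Compound 4 is therefore estimated at 1800 nM, with a likely range from 900 nM to 3600 nM, meaning an expected step of a 1.0-fold lower number from compound 1 to compound 4 (0.01 log units; within the scatter).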

Compound 4, inhibition constant: 846 nM
The estimate for compound 4 lay 2.1-fold (0.33 log units) above the measured number; the measured number lies below the stated range.
By their numbers in this assay, from the lowest: compounds 4, 3, 1 and 2 (each within the scatter of the next, the first and the last beyond it).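

Taking the methoxy group away to leave a plain phenyl gives the first step from compound 1 that clears the scatter in this assay (a 2.2-fold lower number from compound 1 to compound 4 (0.34 log units; beyond the scatter)), although it is a modest one, so the group at this place on the ring does register in the number. Chloro and hydrogen at the same place cannot be told apart (a 1.4-fold lower number from compound 3 to compound 4 (0.16 log units; within the scatter)), so of the two groups tried there, only methoxy is separated from hydrogen. The widest step among these compounds compares the phenyl with the 2-methylphenyl group (a 3.5-fold lower number from compound 2 to compound 4 (0.55 log units; beyond the scatter)), and in this small set no group added to the ring gives a number clearly lower than the bare phenyl of compound 4, with compound 3 level with it within the scatter.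

These compounds leave open how other groups at this place would behave, such as an amine, a carboxylic acid or a longer chain, and whether any of them would take the number clearly lower than that of the bare phenyl. Nothing measured here explains why losing the methoxy group shifts the number in this direction.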